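Swapping acetyl for propyl on the shared core

The compounds below may be only part of what the source reports. "The series", "measured", "known", "first", "only" and "open" are said of these compounds alone.

Measured in a functional assay on KB 3-1 cells (Homo sapiens) for inhibition, with a stated time of 72 h; a higher number here means a weaker inhibitor, a lower number a stronger inhibitor:
Compound 1 `CC(=O)Oc1c(O)cc2oc(-c3ccccc3)cc(=O)c2c1O`: 61600 nM
Compound 2 `COc1cc2oc(-c3ccccc3)cc(=O)c2c(OC)c1OC(C)=O`: > 100000 nM (a limit, not a number)
Compound 3 `O=c1cc(-c2ccccc2)oc2cc(O)c(OCc3ccccc3)c(OCc3ccccc3)c12`: > 100000 nM (a limit, not a number)

Compound 1 is the only one of the three with a true number, 61600 nM. The other two stop at the limit of > 100000 nM in this assay, at which 2 of the 3 values shown sit.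

Compound 4 `CCCOc1c(O)cc2oc(-c3ccccc3)cc(=O)c2c1O` keeps the core of compound 1 and carries propyl in place of acetyl on an oxygen on an aromatic ring. For the measured compounds named here, no measured pair gauges this change, so in this assay no step beyond the scatter is expected, in either direction. The expected step is a 1.2-fold lower number from compound 1 to compound 4 (0.09 log units; within the scatter). Compound 4 is estimated at 50000 nM, with an expected range of 18000 nM to 100000 nM.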

Compound 4, half-maximal inhibitory concentration: > 100000 nM
Compound 4 was reported as a limit; the forecaster's own chance of this, stated with the estimate: 35%; at least 2.0-fold (0.30 log units) between middle value and limit.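

In this assay, for the compounds shown here, the change from acetoxy to propoxy on an oxygen on an aromatic ring reads an at least 1.6-fold higher number from compound 1 to compound 4 (0.21 log units; that floor lies within the scatter) and gives the first measured pair for this position. As far as these compounds go, that floor lies within the scatter, so the pair does not establish a loss, and the full size of the step stays unknown. Compound 4 gives a limit, not a number, and joins the other compounds held there: the limit of > 100000 nM in this assay, at which 3 of the 4 values shown sit.

From the compounds shown here alone, whether an amine or a longer chain on this oxygen would give a true number remains open.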